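Benzyl Against Phenyl on the Aromatic Nitrogen

The source may hold more compounds than are shown below. What is called first, only, known or untested is meant among the compounds shown, and "the series" means these compounds.

compound 1 `COc1ccc(-n2cc(CSC(=S)N3CCN(C(=O)OC(C)(C)C)CC3)nn2)cc1` — > 128000 nM (a limit)
compound 2 `CC(C)(C)OC(=O)N1CCN(C(=S)SCc2cn(-c3ccccc3F)nn2)CC1` — > 128000 nM (a limit)
compound 3 `Cc1ccc(Cn2cc(CSC(=S)N3CCN(C(=O)OC(C)(C)C)CC3)nn2)cc1` — 17300 nM

Among the measured compounds shown here, in a functional assay on PC-3 cells (Homo sapiens) for inhibition, read by MTT assay, with a stated time of 72 h (on this read-out higher numbers stand for weaker inhibition and lower numbers for stronger inhibition), compound 3 gives 17300 nM, the only actual number among the three values shown. For compound 1 the value > 128000 nM is a limit of the assay, not a number. For compound 2 the value > 128000 nM is likewise a limit. Compound 4 `Cc1ccc(-n2cc(CSC(=S)N3CCN(C(=O)OC(C)(C)C)CC3)nn2)cc1` differs from compound 3 by 4-methylphenyl in place of 4-methylbenzyl on an aromatic nitrogen. For the measured compounds named here, two measured steps bear on this change: an at least 7.3-fold lower number from compound 1 to compound 3 (0.86 log units; beyond the scatter) and an at least 7.3-fold lower number from compound 2 to compound 3 (0.86 log units; beyond the scatter). Both of these replace an aryl group on the aromatic nitrogen with 4-methylbenzyl, and both lower the number by a step beyond the scatter. The step from compound 3 to compound 4 runs the other way, from 4-methylbenzyl back to an aryl group, so a higher number is expected in this assay, quite possibly reaching (the limit of > 128000 nM in this assay, at which 2 of the 3 values shown sit). Compound 4 is therefore estimated at 90000 nM, with a range of 25000 nM to 200000 nM. This estimate would mean an expected step of a 5.2-fold higher number from compound 3 to compound 4 (0.72 log units; beyond the scatter).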

Compound 4, half-maximal inhibitory concentration: > 128000 nM
Compound 4 gave a limit, no number; the forecaster's own chance of this, stated with the estimate: 50%; middle value at least 1.4-fold (0.15 log units) from the limit.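

Among the compounds shown here, compounds 3 and 4 share the methyl group on the ring, so unlike the earlier comparisons, which also changed or removed a ring substituent, this pair isolates the change from 4-methylbenzyl to 4-methylphenyl. In this assay, that single change gives an at least 7.3-fold higher number from compound 3 to compound 4 (0.86 log units; beyond the scatter), so the aryl pattern now holds with the methyl group held constant. The steps among compound 1, compound 2 and compound 4 cannot be read, so the three aryl groups cannot be ranked, and compound 3 remains the only compound with an actual number: the limit of > 128000 nM in this assay, at which 3 of the 4 values shown sit.

Going by these compounds, it remains open whether a longer chain, such as 2-phenylethyl, would lower the number further than 4-methylbenzyl does. The compounds shown also leave open whether a benzyl group carrying methoxy or fluorine in place of methyl would keep the number of compound 3.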